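Swapping 3,5-dichlorophenyl for 2,5-dimethylfuran-3-yl in compound 4

The source may report more compounds than this note shows. Statements on the series, on what has been measured and on what is new or still open speak of the compounds shown alone.

In an ADME assay on MT4 cells (Homo sapiens) for cytotoxicity, read by MTT assay (a lower number here means that less compound is tolerated, a higher number that more compound is tolerated), compound 3 (`O=C1c2ccccc2C(=O)N1CCOC(=S)N(C(=O)c1cc(Cl)cc(Cl)c1)c1ccc(Cl)cc1`) gives 32000 nM and so lies within the scatter of both compound 1 (`Cc1ccccc1C(=O)N(C(=S)OCCN1C(=O)c2ccccc2C1=O)c1ccc(Cl)cc1`), at 21000 nM here, and compound 2 (`O=C1c2ccccc2C(=O)N1CCOC(=S)N(C(=O)c1cc(F)ccc1F)c1ccc(Cl)cc1`), at 54000 nM here. Compound 4 (`Cc1cc(C(=O)N(C(=S)OCCN2C(=O)c3ccccc3C2=O)c2ccc(Cl)cc2)c(C)o1`) carries 2,5-dimethylfuran-3-yl in place of 3,5-dichlorophenyl on a carbonyl carbon. The measured exchanges at that same place are (a 1.5-fold higher number from compound 1 to compound 3 (0.18 log units; within the scatter)), (a 1.7-fold lower number from compound 2 to compound 3 (0.23 log units; within the scatter)) and (a 2.6-fold higher number from compound 1 to compound 2 (0.41 log units; beyond the scatter)), the last being modest. Within the data shown here, none of the measured compounds holds a five-membered aromatic ring there. No step beyond the scatter is therefore expected in this assay, and the estimated change is (a 1.1-fold lower number from compound 3 to compound 4 (0.03 log units; within the scatter)). In this assay compound 4 is expected to give 30000 nM within a range of 14000 nM to 65000 nM as its likely span.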

Compound 4, half-maximal cytotoxic concentration: 40000 nM
Compound 4: the middle estimate sits 1.3-fold (0.12 log units) below what was measured, within the range that was stated.
By their numbers in this assay, from the lowest: compounds 1, 3, 4 and 2 (each within the scatter of the next, the first and the last beyond it).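

In this assay, 2,5-dimethylfuran-3-yl brings a five-membered aromatic ring to this place on a carbonyl carbon, and all of its steps to the phenyl-bearing compounds lie within the scatter: a 1.3-fold higher number from compound 3 to compound 4 (0.10 log units; within the scatter), a 1.4-fold lower number from compound 2 to compound 4 (0.13 log units; within the scatter) and a 1.9-fold higher number from compound 1 to compound 4 (0.28 log units; within the scatter). The exchange of 3,5-dichlorophenyl for this ring therefore leaves the number in the range already seen here. Nothing available explains this result.

Still open, as far as these compounds go, is how an amine or a carboxylic acid on this carbonyl carbon would read in this assay. Also open, from the compounds shown here alone, is whether a furan without its two methyl groups would stay within the scatter of compound 4.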